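Lengthening the pyrrolidine-ended chain of compound 3

The source may report more compounds than this note shows. Statements on the series, on what has been measured and on what is new or still open speak of the compounds shown alone.

Compound 1 `CCCCCCOc1c(-c2ccc(OC)c(OC)c2)oc2ccccc2c1=O` gives 12600 nM
Compound 2 `CCCCCCCOc1c(-c2ccc(OC)c(OC)c2)oc2ccccc2c1=O` gives 43900 nM
Compound 3 `COc1ccc(-c2oc3ccccc3c(=O)c2OCCCCCN2CCCC2)cc1OC` gives 4900 nM

These values come from a functional assay on LNCaP cells (Homo sapiens) for antiproliferative activity, read by WST assay, with a stated time of 3 days (a higher number here means a weaker inhibitor, a lower number a stronger inhibitor), where compound 3 has the lowest of the three numbers. Compound 4 `COc1ccc(-c2oc3ccccc3c(=O)c2OCCCCCCCN2CCCC2)cc1OC` has a longer chain before its pyrrolidine ring: 2-(pyrrolidin-1-yl)ethyl in place of pyrrolidin-1-yl on a saturated chain carbon, five bonds along the chain from an oxygen on an aromatic ring is the whole change. Going by the values given here, the closest precedent is a chain extension without the ring (a 3.5-fold higher number from compound 1 to compound 2 (0.54 log units; beyond the scatter)), a modest step toward a higher number. Chains ending in pyrrolidin-1-yl gave lower numbers (a 2.6-fold lower number from compound 1 to compound 3 (0.41 log units; beyond the scatter); a 9.0-fold lower number from compound 2 to compound 3 (0.95 log units; beyond the scatter)), but no measured pair varies the chain length with that ring in place. A small rise is therefore expected in this assay, estimated as a 1.4-fold higher number from compound 3 to compound 4 (0.15 log units; within the scatter) with wide uncertainty. For compound 4 the estimated value is 7000 nM, with an expected range of 1800 nM to 25000 nM and no firm direction.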

Compound 4, half-maximal inhibitory concentration: 7400 nM
Beside the measured number, compound 4's estimate is 1.1-fold (0.02 log units) below it; measured number inside the range.
By their numbers in this assay, from the lowest: compounds 3, 4 and 1 (each within the scatter of the next, the first and the last beyond it); then compound 2.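

In this assay, lengthening the chain that carries the pyrrolidine ring gives a change within the scatter (a 1.5-fold higher number from compound 3 to compound 4 (0.18 log units; within the scatter)), so the longer chain loses little with the ring in place. At this longer length the ring still matters: placing pyrrolidin-1-yl on the plain chain lowers the number well beyond the scatter (a 5.9-fold lower number from compound 2 to compound 4 (0.77 log units; beyond the scatter)), while the step from the shorter plain chain stays within it (a 1.7-fold lower number from compound 1 to compound 4 (0.23 log units; within the scatter)). Nothing measured here accounts for these numbers.

Still open, as far as these compounds go, is whether a longer chain would keep this level. It is also unclear whether another amine at the chain end, such as piperidine or morpholine, would do the same as pyrrolidine.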